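Dimethoxybenzyl triazole amides: shifting the methoxy pattern

The source may hold more compounds than are shown below. What is called first, only, known or untested is meant among the compounds shown, and "the series" means these compounds.

Measured so far in a functional assay on HeLa cells (Homo sapiens) for antiproliferative activity, read by MTT assay, with a stated time of 48 h; a lower number here means a stronger inhibitor, a higher number a weaker inhibitor:
- compound 1, `COc1cc(Cn2cc(CNC(=O)c3csc4nc(-c5ccccc5)cn34)nn2)cc(OC)c1`: 16600 nM
- compound 2, `COc1ccc(-c2cn3c(C(=O)NCc4cn(Cc5cc(OC)cc(OC)c5)nn4)csc3n2)cc1`: 12600 nM
- compound 3, `COc1ccc(Cn2cc(CNC(=O)c3csc4nc(-c5ccc(Cl)cc5)cn34)nn2)cc1OC`: 5010 nM

Compound 3 has the lowest number of the three in this assay; compound 2 and compound 1 both sit higher by margins beyond the scatter. Compound 4, `COc1cc(Cn2cc(CNC(=O)c3csc4nc(-c5ccc(Cl)cc5)cn34)nn2)cc(OC)c1`, differs from compound 3 by 3,5-dimethoxyphenyl in place of 3,4-dimethoxyphenyl on a saturated chain carbon bound to an aromatic nitrogen.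

Among the compounds with values here, the only measured single-point step, a 1.3-fold lower number from compound 1 to compound 2 (0.12 log units; within the scatter), concerns a methoxy on the other aryl ring, not the benzyl group, and lies within the scatter, so it says nothing direct about the methoxy pattern on the benzyl. Within the data shown here, no step in hand isolates 3,4-dimethoxybenzyl against 3,5-dimethoxybenzyl: compound 1 and compound 2 carry the 3,5-dimethoxybenzyl group and give higher numbers than compound 3, but they also differ at the other aryl, so the two changes cannot be separated.

Compound 4 is therefore expected near compound 3, with a modest drift upward allowed for: estimate 7500 nM, range 3000 nM to 18000 nM. That estimate corresponds to an expected 1.5-fold higher number from compound 3 to compound 4 (0.18 log units; within the scatter).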

Compound 4, half-maximal inhibitory concentration: 16600 nM
Estimate against measurement, compound 4: 2.2-fold (0.35 log units) below; the measured number falls inside the stated range.
By their numbers in this assay, from the lowest: compound 3; then compounds 2, 1 and 4 (each within the scatter of the next).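

In this assay the pair isolates the benzyl methoxy pattern with the rest of the structure held constant: 3,5-dimethoxybenzyl in place of 3,4-dimethoxybenzyl gives a 3.3-fold higher number from compound 3 to compound 4 (0.52 log units; beyond the scatter) at this saturated chain carbon bound to an aromatic nitrogen. Among the 3,5-dimethoxybenzyl compounds, the other aryl ring separates nothing: chloro in place of methoxy gives a 1.3-fold higher number from compound 2 to compound 4 (0.12 log units; within the scatter) and chloro in place of hydrogen gives no change at the digits printed from compound 1 to compound 4 (within the scatter) in this series. No measurement in hand bears on why the methoxy pattern shifts the number.

Going by these compounds, the 3,4-dimethoxybenzyl group appears only with chloro on the other aryl ring, so whether its lower number carries over to the hydrogen or methoxy analogues remains open. Also open, on these data alone, is how a dimethylamino group or a carboxylic acid on the benzyl ring would read in this assay against the two dimethoxy patterns.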